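The compounds below may be only part of what the source reports. "The series", "measured", "known", "first", "only" and "open" are said of these compounds alone.

Compound 1 `Cc1cccc(NC(=O)c2cccc(C#N)c2)n1` gives 330 nM in an in vitro assay on HEK-293T cells for displacement of a labelled ligand from metabotropic glutamate receptor 5 (Rattus norvegicus), read by scintillation counting; a lower number here means a stronger inhibitor, a higher number a weaker inhibitor.
Compound 2 `Cc1cccc(NC(=O)c2ccc(-c3cccnc3)c(Cl)c2)n1` gives 2780 nM in this assay.

Of these two numbers, compound 2 has the higher one, and its gap to compound 1 lies beyond the usual scatter, so compound 2 is the weaker inhibitor of the pair. Compound 3 `Cc1cccc(NC(=O)c2ccc(-c3cccnc3)c(C#N)c2)n1` is not yet measured. It differs from compound 2 by cyano in place of chloro on an aromatic carbon. Going by the values given here, no pair of measured compounds shows this exchange on its own. Compound 1 also carries a cyano group and gives the lower number, 330 nM. The step of a 2.8-fold lower number from compound 2 to compound 3 (0.44 log units; beyond the scatter) is therefore expected to run toward a lower number, by a modest amount. Compound 3 is expected to give 1000 nM in this assay, within a range from 300 nM to 3500 nM.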

Compound 3, inhibition constant: 2040 nM
Compound 3: the middle estimate sits 2.0-fold (0.31 log units) below what was measured; measured number inside the range.
By their numbers in this assay, from the lowest: compound 1; then compounds 3 and 2 (each within the scatter of the next).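

In this assay cyano in place of chloro on the carbon ortho to the pyridin-3-yl group gives a 1.4-fold lower number from compound 2 to compound 3 (0.13 log units; within the scatter) and so shows no real change at this position. Pyridin-3-yl in place of hydrogen gives a 6.2-fold higher number from compound 1 to compound 3 (0.79 log units; beyond the scatter) as a step toward a weaker inhibitor, so among these single changes only adding that group moves the number beyond the scatter. Nothing measured here gives a reason for either step. Still open, on these data alone, is how an amine at the cyano position would behave, and whether a carboxylic acid or a longer chain in place of the pyridin-3-yl group would give a number closer to that of compound 1.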